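A few compounds are considered here, and "the series" means these few. Any claim that something is new, unique, unknown or untested is made for them only; others in the source may bear on it.

Three compounds share one core, a coumarin-bearing triazole joined by a carbon chain to an isatin-like ring that carries a substituent on its aromatic part. In a functional assay on HCT-116 cells (Homo sapiens) for inhibition, read by sulforhodamine B assay, with a stated time of 48 h, tested at 50 uM (a lower number here means less inhibition of growth, a higher number more inhibition of growth at the concentration tested), compound 1 `O=C1C(=O)N(CCCn2cc(COc3cc(=O)oc4ccccc34)nn2)c2ccc(Br)cc21` gives 66%, compound 2 `O=C1C(=O)N(CCCCn2cc(COc3cc(=O)oc4ccccc34)nn2)c2ccc([N+](=O)[O-])cc21` gives 53%, and compound 3 `O=C1C(=O)N(CCCCCn2cc(COc3cc(=O)oc4ccccc34)nn2)c2ccc(I)cc21` gives 36%. Compound 2 thus stands second of the three, with compound 1 higher and compound 3 lower, both beyond the usual scatter. Compound 4 `O=C1C(=O)N(CCCCn2cc(COc3cc(=O)oc4ccccc34)nn2)c2ccccc21` differs from compound 2 in one place: hydrogen in place of nitro on an aromatic carbon. For the measured compounds named here, no measured pair shows the effect of this change, so only an expectation is possible. A small step downward or none beyond the scatter is expected, giving a number 8 percentage points lower from compound 2 to compound 4 (within the scatter). Compound 4 is therefore estimated at 45%, within 25% to 65%.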

Compound 4, percent growth inhibition at one concentration: 72%
Compound 4: middle estimate off by 27 percentage points, on the low side, and the stated range ends below it.
By their numbers in this assay, from the lowest: compound 3; then compound 2; then compounds 1 and 4 (each within the scatter of the next).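

In this assay, hydrogen in place of nitro on this aromatic carbon gives a number 19 percentage points higher from compound 2 to compound 4 (beyond the scatter) with the rest of the structure unchanged. For the compounds shown here, this is the first direct reading of this position, and it shows that the nitro group is not needed for growth inhibition at the concentration tested. Nothing shown explains the rise. As far as these compounds go, whether an amine or a methoxy group on this carbon would match hydrogen remains open. So does whether a longer chain would keep this level of inhibition with hydrogen in place.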